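Cyclohexyl to 4-fluorophenyl on the amide-type nitrogen

The source may report more compounds than this note shows. Statements on the series, on what has been measured and on what is new or still open speak of the compounds shown alone.

Values in a functional assay on MCF7 cells (Homo sapiens) for antiproliferative activity, read by MTT assay, with a stated time of 72 h; on this read-out higher numbers stand for weaker inhibition and lower numbers for stronger inhibition:
- compound 1 `O=C1COc2ccc(-c3cnc(Cl)c(NS(=O)(=O)c4ccc(F)cc4)c3)cc2N1C1CCCCC1`: > 40000 nM (a limit)
- compound 2 `O=C1COc2ccc(-c3cccc(NS(=O)(=O)c4ccc(F)cc4)c3)cc2N1`: 18300 nM
- compound 3 `COc1ncc(-c2ccc3c(c2)N(C2CCCCC2)C(=O)CO3)cc1NS(=O)(=O)c1ccc(F)cc1`: 30100 nM

Compound 1 stands at the limit of > 40000 nM in this assay, at which 1 of the 3 values shown sits; this is a limit and not a number. Compound 4 `O=C1COc2ccc(-c3cnc(Cl)c(NS(=O)(=O)c4ccc(F)cc4)c3)cc2N1c1ccc(F)cc1` has yet to be measured in this assay. It has 4-fluorophenyl in place of cyclohexyl on an amide-type nitrogen in a ring.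

Among the measured compounds shown here, no measured step covers this change. For the measured compounds named here, the one step available, an at least 1.3-fold lower number from compound 1 to compound 3 (0.12 log units; that floor lies within the scatter), is methoxy in place of chloro on an aromatic carbon, so it bears only indirectly. Compound 2 carries the amide hydrogen at that nitrogen but differs from compound 1 at a second place as well. Weak inhibition runs through the series, with compound 2 at 18300 nM and compound 3 at 30100 nM, so no step beyond the scatter is expected in either direction. The expected change is an at least 1.3-fold lower number from compound 1 to compound 4 (0.12 log units; that floor lies within the scatter). Compound 4 is expected at 30000 nM, with an estimated range of 12000 nM to 60000 nM.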

Compound 4, half-maximal inhibitory concentration: 32600 nM
Estimate against measurement, compound 4: 1.1-fold (0.04 log units) below; the measured number falls inside the stated range.
By their numbers in this assay, from the lowest: compounds 2, 3 and 4 (each within the scatter of the next). At a limit, above all of these: compound 1.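

This is the only step shown at the amide-type nitrogen in a ring: in this assay, 4-fluorophenyl in place of cyclohexyl gives an at least 1.2-fold lower number from compound 1 to compound 4 (0.08 log units; that floor lies within the scatter). Compound 1 is a limit and not a number, so the step can be read only as a floor and its true size stays open: the limit of > 40000 nM in this assay, at which 1 of the 4 values shown sits.

With an aromatic ring on this nitrogen, compound 4 gives a measured number, 32600 nM, and inhibition in this series remains weak at this position.

From the compounds shown here alone, whether a dimethylaminoethyl chain or a carboxylic acid at this nitrogen would give a step beyond the scatter stays open. Going by these compounds, the effect of the amide hydrogen at this nitrogen also stays open: compound 2 differs from compound 1 at a second place as well.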